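Swapping thiophene for ethynyl on a nucleoside core

A few compounds are considered here, and "the series" means these few. Any claim that something is new, unique, unknown or untested is made for them only; others in the source may bear on it.

Of the compounds shown here, three have been measured in a functional assay on HeLa S3 cells (Homo sapiens) for antiproliferative activity, read by XTT assay, with a stated time of 72 h; on this read-out higher numbers stand for weaker inhibition and lower numbers for stronger inhibition. Compound 1 `C#Cc1cn([C@@H]2O[C@H](CO)[C@@H](O)[C@H]2O)c2ncnc(OC)c12` gives 1730 nM. Compound 3 `C#Cc1cn([C@@H]2O[C@H](CO)[C@@H](O)[C@H]2O)c2ncnc(C)c12`, which carries a methyl in place of methoxy on an aromatic carbon, gives 14700 nM; the measured change is an 8.5-fold higher number from compound 1 to compound 3 (0.93 log units; beyond the scatter). Compound 2 `Cc1nc(N)c2c(-c3cccs3)cn([C@@H]3O[C@H](CO)[C@@H](O)[C@H]3O)c2n1` is recorded only as a limit of the assay, > 20000 nM, so no number is known for it. That limit is the limit of > 20000 nM in this assay, at which 1 of the 3 values shown sits, and compound 2 therefore stands at the weak end of what has been measured, without a fixed position on the scale.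

Compound 4 `C#Cc1cn([C@@H]2O[C@H](CO)[C@@H](O)[C@H]2O)c2nc(C)nc(N)c12` has not yet been measured. It differs from compound 2 in one place: ethynyl in place of thiophen-2-yl on an aromatic carbon. For the measured compounds named here, none of the measured steps involves this exchange, and the single measured step concerns a different group on the core, so it does not bear on the thiophen-2-yl to ethynyl change. Compound 1 and compound 3 show that an ethynyl group on this core can sit anywhere from moderate to weak inhibition, and compound 2 offers only a limit to start from.

Compound 4 is therefore expected to give about 8000 nM in this assay, within a wide range from 1500 nM to 40000 nM. This estimate implies a step of an at least 2.5-fold lower number from compound 2 to compound 4 (0.39 log units; beyond the scatter), which remains uncertain in both size and direction.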

Compound 4, half-maximal inhibitory concentration: > 20000 nM
Compound 4: no number, only a limit (the forecaster's own chance of this, stated with the estimate: 35%); at least 2.5-fold (0.39 log units) between middle value and limit.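

In this assay compound 4 is recorded only as the limit > 20000 nM and not as a number. For the compounds shown here, compound 2 is also recorded only as a limit, so no step from compound 2 to compound 4 can be read. The compounds shown leave open whether ethynyl in place of thiophen-2-yl changes activity on this core at all.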